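The compounds below may be only part of what the source reports. "The series", "measured", "known", "first", "only" and "open" are said of these compounds alone.

Measured so far:
compound 1, `CC(C(=O)NCc1ccc(C(C)(C)C)nc1OC1CCCC1)c1ccc(NS(C)(=O)=O)c(F)c1` — 1.5 nM
compound 2, `CC(C(=O)NCc1ccc(C(C)(C)C)nc1OCc1ccc(F)cc1)c1ccc(NS(C)(=O)=O)c(F)c1` — 0.8 nM

In an assay on cells for antagonist activity at transient receptor potential cation channel subfamily V member 1 (Homo sapiens), read by FLIPR and calcium flux, with a stated time of 6 min (a lower number here means a stronger inhibitor, a higher number a weaker inhibitor), compound 2 gives 0.8 nM, and compound 1 gives 1.5 nM; the step of a 1.9-fold lower number from compound 1 to compound 2 (0.27 log units; within the scatter) lies within the scatter, so the two stand level. Compound 3, `CCCCCSc1nc(C(C)(C)C)ccc1CNC(=O)C(C)c1ccc(NS(C)(=O)=O)c(F)c1`, differs from compound 2 by pentylsulfanyl in place of (4-fluorobenzyl)oxy on an aromatic carbon. Among the compounds with values here, the one measured step touches this same position, and it was small, so no step beyond the scatter is expected here, if anything a slightly higher number. The expected step is a 2.5-fold higher number from compound 2 to compound 3 (0.40 log units; beyond the scatter). Compound 3 is therefore estimated at 2 nM, with a range from 0.6 nM to 7 nM.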

Compound 3, inhibition constant: 3.1 nM
Compound 3: middle estimate off by 1.6-fold (0.19 log units), on the low side, within the range that was stated.
By their numbers in this assay, from the lowest: compounds 2 and 1 (each within the scatter of the next); then compound 3.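

Until now this position had carried only groups joined through oxygen, and those two stood level. Pentylsulfanyl, with sulfur in place of that oxygen and no ring, gives the first steps here beyond the scatter in this assay: a 3.9-fold higher number from compound 2 to compound 3 (0.59 log units; beyond the scatter) and a 2.1-fold higher number from compound 1 to compound 3 (0.32 log units; beyond the scatter). No measured evidence bears on this result.

Sulfur and the loss of the ring change together, so the compounds shown cannot separate them. Where a pentyloxy chain or an amine at this position would fall remains open.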